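A few compounds are considered here, and "the series" means these few. Any claim that something is new, unique, unknown or untested is made for them only; others in the source may bear on it.

Measured in a functional assay on HeLa cells (Homo sapiens) for cytotoxicity, read by CCK-8 assay; on this read-out lower numbers stand for stronger inhibition and higher numbers for weaker inhibition: compound 1, `Oc1cccc(-c2cc(-c3ccco3)cc(-c3cccc(O)c3)n2)c1`, gives 5990 nM; compound 2, `Oc1ccc(-c2cc(-c3ccco3)cc(-c3cccc(O)c3)n2)cc1`, gives 5170 nM; compound 3, `Oc1cccc(-c2cc(-c3ccccn3)cc(-c3ccccc3O)n2)c1`, gives 2020 nM.

Of the three, compound 3 gives the lowest number in this assay. Compound 1 and compound 2 differ by one change, (4-hydroxyphenyl in place of 3-hydroxyphenyl on an aromatic carbon), and that change made a 1.2-fold lower number from compound 1 to compound 2 (0.06 log units; within the scatter). Compound 4, `Oc1ccc(-c2cc(-c3ccccn3)cc(-c3ccccc3O)n2)cc1`, arises from compound 3 by the same kind of change, (4-hydroxyphenyl in place of 3-hydroxyphenyl on an aromatic carbon); here the place is meta to a 2-hydroxyphenyl group and meta to a pyridin-2-yl group, whereas in compound 1 it is meta to a 3-hydroxyphenyl group and meta to a furan-2-yl group. The difference between the two cores is not broken down here. Since the earlier step, a 1.2-fold lower number from compound 1 to compound 2 (0.06 log units; within the scatter), stayed within the scatter, a similarly small step is expected from compound 3 to compound 4, a 1.1-fold lower number from compound 3 to compound 4 (0.03 log units; within the scatter). Compound 4 is therefore estimated at 1900 nM in this assay, between 900 nM and 4000 nM.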

Compound 4, half-maximal inhibitory concentration: > 50000 nM
Compound 4: only a limit was reported; the forecaster's own chance of this, stated with the estimate: 3%; at least 26-fold (1.42 log units) between middle value and limit.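

In this assay the swap of 3-hydroxyphenyl for 4-hydroxyphenyl gave an at least 24-fold higher number from compound 3 to compound 4 (1.39 log units; beyond the scatter), so the small step seen on the core of compound 1 did not carry over to the core of compound 3: the same change on two cores in this assay, a 1.2-fold lower number (0.06 log units; within the scatter) from compound 1 to compound 2 and an at least 24-fold higher number (1.39 log units; beyond the scatter) from compound 3 to compound 4, at least 28-fold (1.45 log units) apart, beyond the scatter of two such steps. From the compounds shown here alone, compound 4 gives > 50000 nM, which is a limit and not a number, so the full size of this step remains unknown: the limit of > 50000 nM in this assay, at which 1 of the 4 values shown sits. The cores differ in carrying furan-2-yl and 3-hydroxyphenyl against pyridin-2-yl and 2-hydroxyphenyl, and the data do not show which of these differences goes with the split.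

Going by these compounds, it remains open how the change behaves on a core carrying only one of these differences. Also open, on these data alone, is how an amine or a carboxylic acid would behave in place of the hydroxyl group on the ring that carries the change.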